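The compounds below may be only part of what the source reports. "The series", "measured", "known", "first", "only" and "open" are said of these compounds alone.

Measured compounds in an ADME assay on WI-38 cells (Homo sapiens) for cytotoxicity, read by MTT assay, with a stated time of 72 h; a higher number here means a weaker inhibitor, a lower number a stronger inhibitor:

- compound 1 `CCN(CC)CCn1cnnc1-c1cc(Oc2ccc(NC(=O)Nc3ccc(F)c(Cl)c3)cc2F)ccn1`: compound 1 gives 28700 nM
- compound 2 `CCN(CC)CCn1cnnc1-c1cc(Oc2ccc(NC(=O)Nc3ccc(Cl)cc3Cl)cc2F)ccn1`: compound 2 gives 4280 nM
- compound 3 `CN(C)CCCn1cnnc1-c1cc(Oc2ccc(NC(=O)Nc3ccc(F)c(Cl)c3)cc2F)ccn1`: compound 3 gives 5370 nM

The pair compound 1 and compound 2 differs at one place, (2,4-dichlorophenyl in place of 3-chloro-4-fluorophenyl on an amide-type nitrogen). That change gives a 6.7-fold lower number from compound 1 to compound 2 (0.83 log units; beyond the scatter).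

Compound 3 carries a different core from compound 1; the difference is (dimethylamino)methyl in place of diethylamino on a saturated chain carbon, two bonds along the chain from an aromatic nitrogen. This change gives a 5.3-fold lower number from compound 1 to compound 3 (0.73 log units; beyond the scatter). Compound 2 and compound 3 lie within the scatter of each other in this assay, so no order is read between them.

Compound 4 `CN(C)CCCn1cnnc1-c1cc(Oc2ccc(NC(=O)Nc3ccc(Cl)cc3Cl)cc2F)ccn1` is not yet measured. It differs from compound 3 by 2,4-dichlorophenyl in place of 3-chloro-4-fluorophenyl on an amide-type nitrogen, and the place of the change reads the same as for compound 1 to compound 2, so this is the same change on the core of compound 3.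

Among the measured compounds shown here, for compound 4 in this assay a step of a 4.5-fold lower number from compound 3 to compound 4 (0.65 log units; beyond the scatter) is expected, to be set beside a 6.7-fold lower number from compound 1 to compound 2 (0.83 log units; beyond the scatter); the expectation rests on that single earlier step and on compound 3 giving 5370 nM, and with only one prior example the step is taken as somewhat smaller. Compound 4 is thus estimated at 1200 nM, with a range from 400 nM to 4000 nM.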

Compound 4, half-maximal inhibitory concentration: 3260 nM
Beside the measured number, compound 4's estimate is 2.7-fold (0.43 log units) below it; measured number inside the range.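

In this assay, 2,4-dichlorophenyl in place of 3-chloro-4-fluorophenyl on the amide-type nitrogen gives a 1.6-fold lower number from compound 3 to compound 4 (0.22 log units; within the scatter), and the size of the earlier step does not carry over: the same change on two cores in this assay, a 6.7-fold lower number (0.83 log units; beyond the scatter) from compound 1 to compound 2 and a 1.6-fold lower number (0.22 log units; within the scatter) from compound 3 to compound 4, 4.1-fold (0.61 log units) apart, beyond the scatter of two such steps

(Dimethylamino)methyl in place of diethylamino gives a 1.3-fold lower number from compound 2 to compound 4 (0.12 log units; within the scatter), and this change does not carry over in size either: the same change on two cores in this assay, a 5.3-fold lower number (0.73 log units; beyond the scatter) from compound 1 to compound 3 and a 1.3-fold lower number (0.12 log units; within the scatter) from compound 2 to compound 4, 4.1-fold (0.61 log units) apart, beyond the scatter of two such steps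

Neither change can therefore be treated as a fixed step across these cores; both steps beyond the scatter start from compound 1, the compound that combines diethylamino with 3-chloro-4-fluorophenyl, but four compounds do not show why the steps differ or whether the same behaviour extends to other members of the series.

From the compounds shown here alone, it remains open whether a cyclic amine such as morpholine in place of diethylamino would also give a step that depends on the group at the amide-type nitrogen. The same question stands for an unsubstituted phenyl on that nitrogen, on either amine chain.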